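This account rests on a few compounds, and the source may have more. Where it says the series, first, only, none or still open, it means among the compounds named here.

Compound 1 `Cc1nc(C(=O)Nc2ccc(Cl)c(-c3nnc4c(Cl)cccn34)c2)cs1` in a functional assay on T47D cells (Homo sapiens) for antiproliferative activity, read by MTT assay, with a stated time of 72 h (on this read-out higher numbers stand for weaker inhibition and lower numbers for stronger inhibition), gives > 100000 nM, which is a limit of the assay rather than a number.
Compound 2 `CS(=O)(=O)c1cccc(C(=O)Nc2ccc(Cl)c(-c3nnc4c(Cl)cccn34)c2)c1` in this assay gives > 100000 nM, again a limit.
Compound 3 `CS(=O)(=O)c1ccc(C(=O)Nc2ccc(Cl)c(-c3nnc4c(Cl)cccn34)c2)cc1` in this assay gives > 100000 nM, also a limit.

Compound 3 therefore stands nowhere that can be ranked: its value is only a limit, and every value shown here is the same kind of limit, as summed up by the limit of > 100000 nM in this assay, at which 3 of the 3 values shown sit. The steps leading to it, a step that the two limits leave unreadable from compound 1 to compound 3 and a step that the two limits leave unreadable from compound 2 to compound 3, cannot be read in size or direction, and the same holds for a step that the two limits leave unreadable from compound 1 to compound 2.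

Compound 4 `O=C(Nc1ccc(Cl)c(-c2nnc3c(Cl)cccn23)c1)c1cccnc1Cl` differs from compound 3 by 2-chloropyridin-3-yl in place of 4-(methylsulfonyl)phenyl on a carbonyl carbon. For the measured compounds named here, no measured step bears readably on this change; all three steps among the measured compounds run between limits. With nothing pointing to a gain in activity, the step that the limit leaves unreadable from compound 3 to compound 4 from compound 3 to compound 4 is expected to be unreadable again, most likely ending at another limit. Compound 4 is accordingly estimated at 150000 nM, with a range from 30000 nM to 1000000 nM.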

Compound 4, half-maximal inhibitory concentration: > 100000 nM
Compound 4: a limit, no number; the forecaster's own chance of this, stated with the estimate: 80%; the middle value is on the limit's open side.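

In this assay, for the compounds shown here, compound 4 gives > 100000 nM, again a limit of the assay, so no step linking it to compound 1, compound 2 or compound 3 can be read. The compounds shown leave open whether any group on this carbonyl carbon would give a measurable value in this assay.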